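Trimming a Pyridinylmethyl Group to Bare Hydrogen

A few compounds are considered here, and "the series" means these few. Any claim that something is new, unique, unknown or untested is made for them only; others in the source may bear on it.

Measured so far, with whole-blood inhibition values:
- compound 1 `C/C(=N\OCc1ccncc1)c1ccc(Sc2cc(F)cc(C3CCOCC3)c2)cc1`: 300 nM
- compound 2 `COC1(c2cc(F)cc(Sc3ccc4c(c3)CC/C4=N\O)c2)CCOCC1`: 290 nM
- compound 3 `C/C(=N\OCC(O)CO)c1ccc(S(=O)(=O)c2cccc(C3CCOCC3)c2)cc1`: 160 nM

These three were tested in a functional assay (blood) for inhibition, with Homo sapiens as the target; a higher number here means a weaker inhibitor, a lower number a stronger inhibitor. Compound 1 gives the highest of the three numbers, but its gap to compound 2 is negligible and even its gap to compound 3 lies within the scatter, so no order among them can be claimed.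

Compound 4 `C/C(=N\O)c1ccc(Sc2cc(F)cc(C3CCOCC3)c2)cc1` is the yet-unmeasured partner of compound 1. The two differ in one spot: hydrogen in place of (pyridin-4-yl)methyl on an oxygen. The (pyridin-4-yl)methyl group leaves and only a hydrogen remains on the oxygen whose other neighbour is a double-bonded nitrogen. Compound 2 also carries a hydrogen on such an oxygen, yet on a different core, so it offers only a loose hint that this arrangement stays in the same range.

Going by the values given here, with no measured step of this kind to lean on, the change is expected to shift this assay by a 1.3-fold higher number from compound 1 to compound 4 (0.12 log units; within the scatter), a small move that may well sit within the scatter, toward a slightly weaker inhibitor if anything. Compound 4 is therefore estimated at 400 nM, with a likely range of 150 nM to 1100 nM.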

Compound 4, half-maximal inhibitory concentration: 80 nM
Beside the measured number, compound 4's estimate is 5.0-fold (0.70 log units) above it; the whole stated range lies above it.
By their numbers in this assay, from the lowest: compounds 4, 3, 2 and 1 (each within the scatter of the next, the first and the last beyond it).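

On the shared core, the oxygen whose other neighbour is a double-bonded nitrogen does not need the (pyridin-4-yl)methyl group for inhibition in this assay. Trimming that group to hydrogen gives a 3.8-fold lower number from compound 1 to compound 4 (0.57 log units; beyond the scatter), which lies beyond the scatter and makes compound 4 the stronger inhibitor of the pair. The earlier compounds differed in more than one place and could not isolate this change, and nothing shown here gives a cause for the step.

On these data alone, it remains open whether a small methyl or a longer chain ending in an amine or a carboxylic acid on this oxygen would match hydrogen, or whether only the (pyridin-4-yl)methyl group gives the higher number. As far as these compounds go, it also remains open whether the same change would give a similar step on a different core.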